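Trifluoromethyl for ethyl on the amide side chain

This account rests on a few compounds, and the source may have more. Where it says the series, first, only, none or still open, it means among the compounds named here.

In an ADME assay on the whole organism (strain CD1) for pharmacokinetics, with Mus musculus as the target, read by LC-MS, at a dose of 5 mg/kg by the intravenous route (on this read-out lower numbers stand for narrower distribution and higher numbers for wider distribution into tissues), compound 1 (`Cc1c(Oc2cnc(C(=O)NCCO)cn2)ccc2c1B(O)OC2`) gives 0.636 L/kg and compound 2 (`Cc1c(Oc2cnc(C(=O)NC(C)CO)cn2)ccc2c1B(O)OC2`) gives 0.603 L/kg with only a small step between them (a 1.1-fold lower number from compound 1 to compound 2 (0.02 log units; within the scatter)). Compound 3 (`CCC[C@H](CO)NC(=O)c1cnc(Oc2ccc3c(c2C)B(O)OC3)cn1`) gives 0.874 L/kg and lies within the scatter of both other values. Compound 4 (`Cc1c(Oc2cnc(C(=O)N[C@@H](CO)CC(F)(F)F)cn2)ccc2c1B(O)OC2`) carries trifluoromethyl in place of ethyl on a saturated chain carbon, two bonds along the chain from an amide-type nitrogen. Going by the values given here, no measured step covers this exchange, but the two side-chain steps leading to compound 3 (a 1.4-fold higher number from compound 1 to compound 3 (0.14 log units; within the scatter) and a 1.4-fold higher number from compound 2 to compound 3 (0.16 log units; within the scatter)) stayed within the scatter. No step beyond the scatter is therefore expected in this assay (a 1.2-fold lower number from compound 3 to compound 4 (0.07 log units; within the scatter)). For compound 4 the estimated value is 0.75 L/kg with an expected range (0.45 L/kg to 1.25 L/kg).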

Compound 4, volume of distribution at steady state: 0.741 L/kg
For compound 4 the middle estimate is 1.0-fold (0.01 log units) above the measured one; the measured number falls inside the stated range.
By their numbers in this assay, from the lowest: compounds 2, 1, 4 and 3 (each within the scatter of the next).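

In this assay, trifluoromethyl in place of ethyl on a saturated chain carbon, two bonds along the chain from an amide-type nitrogen, gives no change beyond the scatter (a 1.2-fold lower number from compound 3 to compound 4 (0.07 log units; within the scatter)). The 3,3,3-trifluoro-1-(hydroxymethyl)propyl chain also stays within the scatter of the two shorter side chains (a 1.2-fold higher number from compound 2 to compound 4 (0.09 log units; within the scatter)) and (a 1.2-fold higher number from compound 1 to compound 4 (0.07 log units; within the scatter)), so a fluorinated chain joins the non-fluorinated ones here. No supporting measurement bears on the cause of this result.

Open, on these data alone, is whether an amine or a carboxylic acid on this side chain would produce a step beyond the scatter in this assay.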